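The source may report more compounds than this note shows. Statements on the series, on what has been measured and on what is new or still open speak of the compounds shown alone.

Compound 1 `COc1cccc(Cn2cnc3sc(-c4cccnc4)cc3c2=O)c1` gives 3480 nM in an assay on isolated protein for inhibition of Rho-associated protein kinase 2 (Homo sapiens), read by radiometric assay and 33P incorporation, with a stated time of 40 min, in the presence of a further agent that is not named here (on this read-out lower numbers stand for stronger inhibition and higher numbers for weaker inhibition), and stands highest of the two numbers recorded in this assay. Compound 2 `COc1cccc(Cn2cnc3sc(-c4ccnc(F)c4)cc3c2=O)c1` gives 83 nM in this assay; the step of a 42-fold lower number from compound 1 to compound 2 (1.62 log units; beyond the scatter) is the only one in hand. Compound 3 `COc1cccc(Cn2cnc3sc(-c4ccc(N)nc4)cc3c2=O)c1` is not yet measured in this assay. Its difference from compound 1 is amino in place of hydrogen on an aromatic carbon. Among the compounds with values here, the one measured step replaces the whole pyridin-3-yl with 2-fluoropyridin-4-yl, so it alters the same ring but not in the way of compound 3, and it reads on the present change only loosely: the ring tolerates alteration, with a large lowering of the number. Within the data shown here, with no closer precedent, a smaller step downward in this assay is expected for compound 3, a 3.5-fold lower number from compound 1 to compound 3 (0.54 log units; beyond the scatter), and the estimate for compound 3 in this assay is 1000 nM, in the range 250 nM to 4000 nM.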

Compound 3, half-maximal inhibitory concentration: > 10000 nM
Compound 3: a limit, no number; the forecaster's own chance of this, stated with the estimate: 5%; at least 10-fold (1.00 log units) between middle value and limit.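

Within the data shown here, replacing pyridin-3-yl with 6-aminopyridin-3-yl gives an at least 2.8-fold higher number from compound 1 to compound 3 (0.45 log units; beyond the scatter), so the only change seen so far on this ring that raises the number is amino on the aromatic carbon next to the ring nitrogen, para to a large group. Against 2-fluoropyridin-4-yl, the same 6-aminopyridin-3-yl group gives an at least 120-fold higher number from compound 2 to compound 3 (2.08 log units; beyond the scatter), which widens the span of outcomes for this one ring well beyond what the earlier lowering showed. Compound 3 stands at a limit of this assay and not at a number, so both steps give only a minimum size: the limit of > 10000 nM in this assay, at which 1 of the 3 values shown sits.

Open, going by these compounds, is how far past the limit compound 3 lies. Also open, on these data alone, is whether a methoxy or an acetamide in the same place would read as amino does, and whether fluorine alone on the pyridin-3-yl ring of compound 1 would lower the number.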